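An Isopropylsulfonyl Variant of Compound 2

The compounds below may be only part of what the source reports. "The series", "measured", "known", "first", "only" and "open" are said of these compounds alone.

Compound 1, `CCN1CCc2nc(C#Cc3ccccc3)sc2C1`, gives 1200 nM in an assay on HEK293 cells for negative allosteric modulation of metabotropic glutamate receptor 5 (Homo sapiens), read by FLIPR, with a stated time of 1 h; on this read-out higher numbers stand for weaker inhibition and lower numbers for stronger inhibition.
Compound 2, `O=C(C1CCC1)N1CCc2nc(C#Cc3ccccc3)sc2C1`, gives 370 nM in this assay.
Compound 3, `N#Cc1cccc(C(=O)N2CCc3nc(C#Cc4ccccc4)sc3C2)c1`, gives only a limit, > 10000 nM, in this assay.

Compound 2 holds the lowest of the two numbers shown; the step to it, a 3.2-fold lower number from compound 1 to compound 2 (0.51 log units; beyond the scatter), came with cyclobutylcarbonyl in place of ethyl on an amine nitrogen in a ring. Compound 3 sits at the limit of > 10000 nM in this assay, at which 1 of the 3 values shown sits, after an at least 27-fold higher number from compound 2 to compound 3 (1.43 log units; beyond the scatter).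

Compound 4, `CC(C)S(=O)(=O)N1CCc2nc(C#Cc3ccccc3)sc2C1`, differs from compound 2 by isopropylsulfonyl in place of cyclobutylcarbonyl on an amine nitrogen in a ring. Both measured steps bear on this position: the modest one, a 3.2-fold lower number from compound 1 to compound 2 (0.51 log units; beyond the scatter), and the large one, an at least 27-fold higher number from compound 2 to compound 3 (1.43 log units; beyond the scatter). The entering group brings no ring and no aromatic carbon, unlike the 3-cyanophenyl of compound 3. Compound 4 is therefore expected to stay near compound 2, a 1.6-fold higher number from compound 2 to compound 4 (0.21 log units; within the scatter). Compound 4 is estimated at 600 nM, ranging from 200 nM to 2500 nM.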

Compound 4, half-maximal inhibitory concentration: 11 nM
Compound 4: middle estimate off by 55-fold (1.74 log units), on the high side; measured number outside the range, below it.
By their numbers in this assay, from the lowest: compound 4; then compound 2; then compound 1. At a limit, above all of these: compound 3.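

Going by these compounds alone, at this amine nitrogen in a ring, isopropylsulfonyl opens far more room for change than the earlier compounds showed: in this assay there is a 34-fold lower number from compound 2 to compound 4 (1.53 log units; beyond the scatter), and there is also a 110-fold lower number from compound 1 to compound 4 (2.04 log units; beyond the scatter). The position therefore responds strongly to a group with the same count of heavy atoms, so that size alone does not set the read-out here. Nothing shown gives a measured property that accounts for this gain.

The compounds shown leave open whether the gain belongs to the sulfonyl or to the isopropyl part. Isopropylcarbonyl, methylsulfonyl or phenylsulfonyl on the same nitrogen would separate the two.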